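The compounds below may be only part of what the source reports. "The series", "measured", "known", "first", "only" and "open" are said of these compounds alone.

Measured compounds:
- Compound 1, `O=C(/C=C/c1cn(-c2ccccc2)nc1-c1ccsc1)c1ccccc1`, gives 5100 nM in a functional assay on HCT-116 cells (Homo sapiens) for inhibition, read by sulforhodamine B assay, with a stated time of 72 h; on this read-out higher numbers stand for weaker inhibition and lower numbers for stronger inhibition.
- Compound 2, `COc1ccc(C(=O)/C=C/c2cn(-c3ccccc3)nc2-c2ccsc2)c(OC)c1`, gives 2200 nM in this assay.
- Compound 3, `O=C(/C=C/c1cn(-c2ccccc2)nc1-c1cccnc1)c1ccsc1`, gives 1300 nM in this assay.

Compound 3 has the lowest of these three numbers, though its gap to compound 2 lies within the usual scatter; only its gap to compound 1 is beyond it. Compound 4, `O=C(/C=C/c1cn(-c2ccccc2)nc1-c1cccnc1)c1cc[nH]c1`, differs from compound 3 by 1H-pyrrol-3-yl in place of thiophen-3-yl on a carbonyl carbon. Among the compounds with values here, the only measured step at the same place is a 2.3-fold lower number from compound 1 to compound 2 (0.37 log units; beyond the scatter), which swaps one carbonyl-bound aryl for another; it shows that changes at this position can move the number modestly, but gives no guidance on this particular swap. A step of no more than modest size in this assay is therefore expected, a 1.5-fold higher number from compound 3 to compound 4 (0.19 log units; within the scatter), and compound 4 is estimated at 2000 nM, with a range from 700 nM to 6000 nM.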

Compound 4, half-maximal inhibitory concentration: 7400 nM
Beside the measured number, compound 4's estimate is 3.7-fold (0.57 log units) below it, and the stated range ends below it.
By their numbers in this assay, from the lowest: compounds 3 and 2 (each within the scatter of the next); then compounds 1 and 4 (each within the scatter of the next).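

In this assay, 1H-pyrrol-3-yl in place of thiophen-3-yl gives a 5.7-fold higher number from compound 3 to compound 4 (0.76 log units; beyond the scatter), meaning weaker inhibition. So two five-membered aromatic rings with the same heavy-atom count are not interchangeable on this carbonyl carbon: exchanging sulfur for a ring nitrogen that carries a hydrogen-bond donor moves the number beyond the usual scatter. No available evidence explains this difference.

The compounds shown leave open whether the ring's nitrogen hydrogen matters. A 1-methyl-1H-pyrrol-3-yl or furan-3-yl group at this position would help separate that hydrogen from the change of ring atom.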